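A few compounds are considered here, and "the series" means these few. Any claim that something is new, unique, unknown or untested is made for them only; others in the source may bear on it.

Measured in a functional assay on DU-145 cells (Homo sapiens) for inhibition, read by trypan blue exclusion, with a stated time of 96 h; on this read-out lower numbers stand for stronger inhibition of growth and higher numbers for weaker inhibition of growth:
Compound 1 `COc1ccc(/C=C(\C(=O)c2ccc(Br)cc2)S(=O)(=O)c2ccc(Br)cc2)cc1`: 25000 nM
Compound 2 `O=C(/C(=C\c1ccc(Br)c(O)c1)S(=O)(=O)c1ccc(Br)cc1)c1ccc(Br)cc1`: 50000 nM
Compound 3 `O=C(/C(=C\c1ccc(OC(F)(F)F)cc1)S(=O)(=O)c1ccc(Br)cc1)c1ccc(Br)cc1`: 25000 nM

Compound 3, at 25000 nM, stands level with compound 1 at the digits reported. Compound 2 reads 50000 nM, which is still within the usual scatter of compound 3.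

The compound to be measured next is compound 4 `O=C(/C(=C\c1ccc(F)cc1)S(=O)(=O)c1ccc(Br)cc1)c1ccc(Br)cc1`. It keeps the rest of compound 3 and exchanges one group: fluoro in place of trifluoromethoxy on an aromatic carbon. In words, this is fluoro in place of trifluoromethoxy on an aromatic carbon, para to a large group.

Among the compounds with values here, two measured steps bear on this exchange, though neither tests it directly. The closer is no change at the digits printed from compound 1 to compound 3 (within the scatter), where trifluoromethyl took the place of methyl on an oxygen on an aromatic ring. The other is a 2.0-fold higher number from compound 1 to compound 2 (0.30 log units; within the scatter), where 4-bromo-3-hydroxyphenyl took the place of 4-methoxyphenyl. Within the data shown here, no measured compound carries fluoro in this place, so the data give no direction for the exchange. With both of these steps within the scatter, no shift beyond the scatter is expected in this assay. The expected change is no change at the digits printed from compound 3 to compound 4 (within the scatter). For compound 4 the estimated value is 25000 nM, with an expected range from 10000 nM to 60000 nM.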

Compound 4, concentration for 50% growth inhibition: 4000 nM
Estimate against measurement, compound 4: 6.3-fold (0.80 log units) above; the measured number lies below the stated range.
By their numbers in this assay, from the lowest: compound 4; then compounds 1, 3 and 2 (each within the scatter of the next).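

In this assay, within the data shown here, fluoro on this aromatic carbon, para to a large group, gives the first steps beyond the scatter: a 6.3-fold lower number from compound 3 to compound 4 (0.80 log units; beyond the scatter) where it replaces trifluoromethoxy, a 6.3-fold lower number from compound 1 to compound 4 (0.80 log units; beyond the scatter) where it replaces methoxy, and a 13-fold lower number from compound 2 to compound 4 (1.10 log units; beyond the scatter) where 4-fluorophenyl replaces 4-bromo-3-hydroxyphenyl. The earlier exchanges on this ring had all stayed within the scatter, so the position looked insensitive, whereas compound 4 now stands apart from all three other compounds as the most potent on this read-out. The data shown offer no measured explanation for this difference.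

The compounds shown leave open whether the gain is particular to fluoro or would also appear with another group here, such as chloro, a nitrile or a plain hydrogen. Going by these compounds, it is also open whether fluoro would keep this effect if the two bromo groups elsewhere on the shared core gave way to other groups, for instance an amine.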